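The source may report more compounds than this note shows. Statements on the series, on what has been measured and on what is new or still open speak of the compounds shown alone.

Working notes on the series. All three measured compounds share one core and differ only in the group on the sulfonyl sulfur. Compound 1 `O=C(NS(=O)(=O)c1ccc(F)cc1)c1ccc(Nc2nc(NC3(c4ccc(Cl)cc4)CC3)nc(OCC(F)(F)F)n2)cc1` carries 4-fluorophenyl there; in a physicochemical assay for permeability, using PAMPA, at pH 7.4 (on this read-out lower numbers stand for lower permeability and higher numbers for higher permeability), compound 1 gives 193 nm/s. Compound 2 `CC(C)(C)NC(=O)NCCS(=O)(=O)NC(=O)c1ccc(Nc2nc(NC3(c4ccc(Cl)cc4)CC3)nc(OCC(F)(F)F)n2)cc1` gives 49 nm/s in this assay, and compound 3 `CC(C)OC(=O)NCCS(=O)(=O)NC(=O)c1ccc(Nc2nc(NC3(c4ccc(Cl)cc4)CC3)nc(OCC(F)(F)F)n2)cc1` gives 71 nm/s. The steps between them: a 3.9-fold lower number from compound 1 to compound 2 (0.60 log units; beyond the scatter); a 2.7-fold lower number from compound 1 to compound 3 (0.43 log units; beyond the scatter); a 1.4-fold higher number from compound 2 to compound 3 (0.16 log units; within the scatter). Compound 3 thus stands second highest of the three numbers, with compound 2 within the scatter of it and compound 1 beyond it on the high side.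

Compound 4 `COC(=O)NCCS(=O)(=O)NC(=O)c1ccc(Nc2nc(NC3(c4ccc(Cl)cc4)CC3)nc(OCC(F)(F)F)n2)cc1` differs from compound 3 in one place: methyl in place of isopropyl on an oxygen next to a carbonyl group. The step that bears most directly on this is a 1.4-fold higher number from compound 2 to compound 3 (0.16 log units; within the scatter), which exchanged one substituent on a carbonyl carbon for another without leaving the scatter. The larger steps of a 3.9-fold lower number from compound 1 to compound 2 (0.60 log units; beyond the scatter) and a 2.7-fold lower number from compound 1 to compound 3 (0.43 log units; beyond the scatter) replaced the whole group on the sulfonyl sulfur and are only a loose guide here. A change confined to the group on an oxygen next to a carbonyl group is therefore expected to move this assay little, with the expected step being a 1.3-fold lower number from compound 3 to compound 4 (0.11 log units; within the scatter), which stays within the scatter. Compound 4 is estimated at 55 nm/s, in the range 30 nm/s to 100 nm/s.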

Compound 4, apparent permeability: 39 nm/s
For compound 4 the middle estimate is 1.4-fold (0.15 log units) above the measured one; low and high end bracket the measured number.
By their numbers in this assay, from the lowest: compounds 4, 2 and 3 (each within the scatter of the next); then compound 1.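

Methyl in place of isopropyl on an oxygen next to a carbonyl group gives a 1.8-fold lower number from compound 3 to compound 4 (0.26 log units; within the scatter) in this assay, so this first change confined to that oxygen stays within the scatter despite the smaller group. The step of a 1.3-fold lower number from compound 2 to compound 4 (0.10 log units; within the scatter) also stays within the scatter, which leaves methoxy and (tert-butyl)amino on the carbonyl carbon indistinguishable here and places compounds 2, 3 and 4 in one band, with no order among them to be read. The step of a 4.9-fold lower number from compound 1 to compound 4 (0.69 log units; beyond the scatter) lies beyond the scatter, so the gap to compound 1 persists with the smallest group yet shown on this oxygen, and no measurement at hand accounts for these steps.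

The compounds shown leave open whether this oxygen would stay as undemanding with a group unlike isopropyl and methyl, such as a phenyl ring, a longer chain or a chain ending in a carboxylic acid or an amine. They also leave open whether any replacement at this end of the 2-aminoethyl chain on the sulfonyl sulfur could bring the number in this assay closer to that of compound 1.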